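Working notes: cytotoxicity limits and a new amino analogue

The compounds below may be only part of what the source reports. "The series", "measured", "known", "first", "only" and "open" are said of these compounds alone.

Compound 1 `CCCCCOc1nc(N)nc2c1ncn2/C=C1/CC1(CO)CO` carries a pentyloxy group on an aromatic carbon of its core. In an ADME assay on Akata cells (Homo sapiens) for cytotoxicity, with a stated time of 7 days (a lower number here means that less compound is tolerated, a higher number that more compound is tolerated), compound 1 gives > 20000 nM, which is a limit of the assay and not a number. Compound 2 `Nc1nc(NC2CCCC2)c2ncn(/C=C3/CC3(CO)CO)c2n1` carries cyclopentylamino on that aromatic carbon instead. In this assay compound 2 gives > 20000 nM, again a limit. Compound 3 `COCCOc1nc(N)nc2c1ncn2/C=C1/CC1(CO)CO` carries 2-methoxyethoxy there. In this assay compound 3 gives > 20000 nM, also a limit. Compound 1 therefore stands at the limit, where every value in the set sits (the limit of > 20000 nM in this assay, at which 3 of the 3 values shown sit), so no ordering among the three is possible.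

The steps a step that the two limits leave unreadable from compound 1 to compound 2, a step that the two limits leave unreadable from compound 1 to compound 3 and a step that the two limits leave unreadable from compound 2 to compound 3 are all unreadable in size because each value rests at the limit (the limit of > 20000 nM in this assay, at which 3 of the 3 values shown sit).

Compound 4 `CC(C)Nc1nc(N)nc2c1ncn2/C=C1/CC1(CO)CO` is not yet measured. The change from compound 1 is isopropylamino in place of pentyloxy on an aromatic carbon. The step that most resembles it, a step that the two limits leave unreadable from compound 1 to compound 2, exchanged pentyloxy for a cyclic amino group and gave no readable size. Within the data shown here, no measured step bears readably on the new change, and none beyond the scatter is expected in this assay. Compound 4 is expected to give 30000 nM, in a range of 15000 nM to 100000 nM, an expected step that the limit leaves unreadable from compound 1 to compound 4.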

Compound 4, half-maximal cytotoxic concentration: > 24000 nM
Compound 4 was reported as a limit (the forecaster's own chance of this, stated with the estimate: 85%); the middle value lies beyond the limit too.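

In this assay compound 4 gives > 24000 nM, a limit of the assay and not a number. Among these compounds, no step between compound 4 and compound 1, compound 2 or compound 3 can be read in size. The compounds shown leave open where the half-maximal cytotoxic concentration of any of these four compounds lies, and whether exchanging the group on that aromatic carbon changes it at all.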